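Trifluoromethyl in place of methyl: working notes on the series

The compounds below may be only part of what the source reports. "The series", "measured", "known", "first", "only" and "open" are said of these compounds alone.

In a physicochemical assay, read by spectrophotometry, with a stated time of 25 min (a higher number here means a weaker inhibitor, a lower number a stronger inhibitor), compound 1 `Cc1ccc2nc(NCCCCOc3cc(O)c4c(=O)cc(-c5ccccc5)oc4c3)sc2c1` gives 28.1 ug/mL. On the same read-out, compound 2 `O=c1cc(-c2ccccc2)oc2cc(OCCCCNc3nc4ccc(Br)cc4s3)cc(O)c12` gives 16.1 ug/mL and compound 3 `O=c1cc(-c2ccccc2)oc2cc(OCCCCNc3nc4ccc(F)cc4s3)cc(O)c12` gives 14.7 ug/mL. Compound 1 is therefore not separated from either of the other two compounds.

Compound 4 `O=c1cc(-c2ccccc2)oc2cc(OCCCCNc3nc4ccc(C(F)(F)F)cc4s3)cc(O)c12` has yet to be measured in this assay. Its difference from compound 1 is trifluoromethyl in place of methyl on an aromatic carbon.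

Within the data shown here, three measured steps bear on this change. Replacing methyl with bromo gives a 1.7-fold lower number from compound 1 to compound 2 (0.24 log units; within the scatter). Replacing methyl with fluoro gives a 1.9-fold lower number from compound 1 to compound 3 (0.28 log units; within the scatter). Replacing bromo with fluoro gives a 1.1-fold lower number from compound 2 to compound 3 (0.04 log units; within the scatter). Among the measured compounds shown here, all three stay within the scatter, and none of the three compounds goes against this, though they cover only three groups. For the measured compounds named here, the data hold no measured trifluoromethyl example, so the range has to stay wide.

The closest guide is the pair of steps away from methyl, so a small move in the same direction is expected, with no step beyond the scatter. The estimated change is a 1.8-fold lower number from compound 1 to compound 4 (0.24 log units; within the scatter). For compound 4 the estimated value is 16 ug/mL, with an expected range of 8.5 ug/mL to 30 ug/mL.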

Compound 4, half-maximal inhibitory concentration: 16.3 ug/mL
For compound 4 the middle estimate is 1.0-fold (0.01 log units) below the measured one, within the range that was stated.
By their numbers in this assay, from the lowest: compounds 3, 2, 4 and 1 (each within the scatter of the next).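

In this assay, trifluoromethyl on this aromatic carbon of the six-membered aromatic ring brings 4 heavy atoms in place of the 1 of methyl, and the step stays small (a 1.7-fold lower number from compound 1 to compound 4 (0.24 log units; within the scatter)). The earlier steps shown here covered only methyl, bromo and fluoro; the two new comparisons extend them to a multi-atom fluorinated group, with trifluoromethyl in place of fluoro (a 1.1-fold higher number from compound 3 to compound 4 (0.04 log units; within the scatter)) and trifluoromethyl in place of bromo (a 1.0-fold higher number from compound 2 to compound 4 (0.01 log units; within the scatter)). All four groups at this position now stand within the scatter of one another, so the read-out does not separate them, and no supporting measurement is available to explain this flat picture.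

The compounds shown carry only methyl, bromo, fluoro and trifluoromethyl at this position, so it remains open whether an amine or a carboxylic acid on this aromatic carbon would stay within the same scatter. Among these compounds, no step at this position yet lies beyond the scatter, which also leaves open how far a methoxy group or a longer alkyl chain there could move the read-out.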